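A few compounds are considered here, and "the series" means these few. Any claim that something is new, unique, unknown or untested is made for them only; others in the source may bear on it.

Compound 1 `COc1ccc([C@H]2NC(=O)O[C@H]2CO)cc1` gives 46500 nM in a functional assay on DU-145 cells (Homo sapiens) for cytotoxicity; on this read-out higher numbers stand for weaker inhibition and lower numbers for stronger inhibition. Compound 2 `COc1ccc([C@H]2NC(=O)O[C@@H]2CO)cc1` gives 40600 nM in this assay. Among the compounds with values here, the single measured step is a 1.1-fold lower number from compound 1 to compound 2 (0.06 log units; within the scatter), and it rests on (the fact that compounds 1 and 2 differ only in the configuration as drawn). Compound 2 has the lower of the two numbers shown, but the gap to compound 1 is within the scatter and carries no order between them.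

Compound 3 `C=C[C@H]1OC(=O)N[C@@H]1c1ccc(OC)cc1` differs from compound 2 by vinyl in place of hydroxymethyl on a saturated ring carbon. Within the data shown here, no measured step bears on this exchange: the one step recorded concerns configuration alone and was within the scatter, so it offers no guide to a change of substituent. With nothing to point either way, the expectation for compound 3 in this assay is a step of a 1.2-fold lower number from compound 2 to compound 3 (0.06 log units; within the scatter), that is, nothing beyond the scatter, with wide uncertainty. Compound 3 is therefore estimated at 35000 nM, expected to fall between 12000 nM and 100000 nM.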

Compound 3, half-maximal inhibitory concentration: 32800 nM
The estimate for compound 3 lay 1.1-fold (0.03 log units) above the measured number; measured number inside the range.
By their numbers in this assay, from the lowest: compounds 3, 2 and 1 (each within the scatter of the next).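

Within the data shown here, the earlier pair varied configuration only, so this is the first change of substituent, made on the saturated ring carbon next to the ring oxygen. In this assay the exchange gives a 1.2-fold lower number from compound 2 to compound 3 (0.09 log units; within the scatter) even though vinyl carries neither the hydrogen-bond donor nor the hydrogen-bond acceptor counted on hydroxymethyl, so for this pair neither is needed to hold the number within the scatter. Nothing at hand accounts for this outcome, since the only available fact concerns configuration and not this exchange.

Going by these compounds, whether an amine, a carboxylic acid or a longer chain on this carbon would move the number beyond the scatter remains open. Also open, on these data alone, is whether vinyl gives the same result in the configuration of compound 1.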